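A Methyl-Bearing Ring in Place of a Difluoro Ring

This account rests on a few compounds, and the source may have more. Where it says the series, first, only, none or still open, it means among the compounds named here.

For the measured compounds named here, compound 3 `Cc1cc(NC(=O)Cn2nnc(-c3ccc(F)c(F)c3)n2)n(C2CCCCC2)n1` gives 116 nM in an assay on HEK293 cells for activation of Kir3.1/Kir3.2 (Homo sapiens), read by thallium flux (a higher number here means that more compound is needed for the effect, a lower number that less compound is needed), the second highest of the three numbers measured so far; compound 1 `Cc1cc(NC(=O)Cn2nnc(-c3ccccc3)n2)n(C2CCCCC2)n1` gives 96 nM, and compound 2 `Cc1cc(NC(=O)Cn2nnc(-c3ccc(Cl)c(Cl)c3)n2)n(C2CCCCC2)n1` gives 1220 nM. Compound 4 `Cc1ccc(-c2nnn(CC(=O)Nc3cc(C)nn3C3CCCCC3)n2)cc1` has not been measured; it differs from compound 3 by 4-methylphenyl in place of 3,4-difluorophenyl on an aromatic carbon. Going by the values given here, two measured steps bear on this change: a 1.2-fold higher number from compound 1 to compound 3 (0.08 log units; within the scatter), while a 13-fold higher number from compound 1 to compound 2 (1.10 log units; beyond the scatter) and an 11-fold lower number from compound 2 to compound 3 (1.02 log units; beyond the scatter). The fluorine pair leaves the number close to that of compound 1, whereas the chlorine pair raises it sharply. A methyl group is a different case again, so a moderate rise is expected, a 2.6-fold higher number from compound 3 to compound 4 (0.41 log units; beyond the scatter). Compound 4 is estimated at 300 nM, with a range from 100 nM to 1000 nM.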

Compound 4, half-maximal effective concentration: 111 nM
Compound 4: middle estimate off by 2.7-fold (0.43 log units), on the high side, within the range that was stated.
By their numbers in this assay, from the lowest: compounds 1, 4 and 3 (each within the scatter of the next); then compound 2.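

In this assay, 4-methylphenyl and 3,4-difluorophenyl cannot be told apart at this position (a 1.0-fold lower number from compound 3 to compound 4 (0.02 log units; within the scatter)), and methyl in place of hydrogen on the phenyl ring of compound 1 also leaves the number within the scatter (a 1.2-fold higher number from compound 1 to compound 4 (0.06 log units; within the scatter)). Among these four compounds, only the 3,4-dichlorophenyl group of compound 2 stands apart (an 11-fold lower number from compound 2 to compound 4 (1.04 log units; beyond the scatter)), so the methyl group does not share its large rise. Nothing measured here explains why. From the compounds shown here alone, whether a methoxy group or a single chlorine on the phenyl ring would stay with the first three compounds or move towards compound 2 remains open.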